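A few compounds are considered here, and "the series" means these few. Any claim that something is new, unique, unknown or untested is made for them only; others in the source may bear on it.

Three compounds have been measured in an assay on C3H 10T1/2 cells for inhibition of Sonic hedgehog protein (Mus musculus), read by a luciferase reporter; on this read-out higher numbers stand for weaker inhibition and lower numbers for stronger inhibition:

Compound 1 `Cc1nc(C(F)(F)F)ccc1C(=O)Nc1ccc(Cl)c(-c2nc3c(n2C)CCCC3)c1`: 150 nM
Compound 2 `Cc1nc(C(F)(F)F)ccc1C(=O)Nc1ccc(Cl)c(C(=O)Nc2ccccc2)c1`: 140 nM
Compound 3 `Cc1nc(C(F)(F)F)ccc1C(=O)Nc1ccc(Cl)c(-c2ncccn2)c1`: 8000 nM

Compound 3 gives the highest number of the three; its nearest neighbour is compound 1, which lies a 53-fold higher number from compound 1 to compound 3 (1.73 log units; beyond the scatter), and compound 2 lies a 57-fold higher number from compound 2 to compound 3 (1.76 log units; beyond the scatter). Compound 4 `Cc1nc(C(F)(F)F)ccc1C(=O)Nc1ccc(Cl)c(-c2cnc3ccccc3n2)c1` has not been measured; it differs from compound 3 by quinoxalin-2-yl in place of pyrimidin-2-yl on an aromatic carbon.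

Going by the values given here, two measured steps bear on this change. In both, the group on that aromatic carbon was exchanged, and the pyrimidin-2-yl of compound 3 stood out as the weakest of the three groups by a wide margin. The quinoxalin-2-yl that enters in compound 4 resembles the group of compound 1 in its count of heavy atoms and in being a fused two-ring unit, so the large steps to compound 3 from compound 1 and from compound 2 are taken as the guide. Compound 4 is therefore expected to give a markedly lower number than compound 3 in this assay, a step of about a 20-fold lower number from compound 3 to compound 4 (1.30 log units; beyond the scatter). Compound 4 is estimated at 400 nM, within a range from 100 nM to 2500 nM.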

Compound 4, half-maximal inhibitory concentration: 52 nM
Compound 4: the middle estimate sits 7.7-fold (0.89 log units) above what was measured; measured number outside the range, below it.
By their numbers in this assay, from the lowest: compound 4; then compounds 2 and 1 (each within the scatter of the next); then compound 3.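

In this assay, the step of a 150-fold lower number from compound 3 to compound 4 (2.19 log units; beyond the scatter) shows that this position does not reject every ring system with two ring nitrogens: the group that leaves and the group that enters have the same counts of hydrogen-bond donors and acceptors, and the large change goes with the added six-membered aromatic ring of carbon only. Compound 4 is also the strongest of the four, and the steps of a 2.7-fold lower number from compound 2 to compound 4 (0.43 log units; beyond the scatter) and a 2.9-fold lower number from compound 1 to compound 4 (0.46 log units; beyond the scatter) are both modest but beyond the scatter, so the two larger groups that had matched each other do not mark the best level reached at this position, and the second step shows that groups with the same count of heavy atoms can still differ. The compounds shown give no measured reason for any of these steps.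

Going by these compounds, it remains open how much of the gain belongs to the carbon-only ring and how much to the ring nitrogens, which a naphthalen-2-yl or a plain phenyl at this position would help to separate. On these data alone, it is also open whether a smaller addition to the pyrimidin-2-yl, such as an amine or a methoxy group, would recover any of the lost inhibition.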